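Adding a dimethylamino group to a weak chalcone-type inhibitor

This account rests on a few compounds, and the source may have more. Where it says the series, first, only, none or still open, it means among the compounds named here.

For the measured compounds named here, the two compounds measured so far share one core: compound 1 `O=C(/C=C/c1ccncc1)c1cccc(C(F)(F)F)c1` and compound 2 `O=C(/C=C/c1ccncc1)c1ccccc1`. In a functional assay with Rattus norvegicus as the target (a higher number here means a weaker inhibitor, a lower number a stronger inhibitor), compound 1 gives 41000 nM, and compound 2 gives 49000 nM. Compound 2 stands at the highest of the two numbers, but its nearest neighbour, compound 1, lies within the scatter of it, so the two cannot be ranked. Going by the values given here, the single measured step, a 1.2-fold higher number from compound 1 to compound 2 (0.08 log units; within the scatter), shows that swapping a trifluoromethyl for a hydrogen on the aromatic carbon left the number essentially unchanged.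

Compound 3 `CN(C)c1cccc(C(=O)/C=C/c2ccncc2)c1` has not been measured yet. It differs from compound 2 in one place: dimethylamino in place of hydrogen on an aromatic carbon. Among the compounds with values here, the only step that bears on this change is the one from compound 1 to compound 2, which concerns the same aromatic carbon and stayed within the scatter. On that basis a step of a 1.2-fold lower number from compound 2 to compound 3 (0.09 log units; within the scatter) is expected in this assay, that is, no change beyond the scatter. Compound 3 is therefore estimated at 40000 nM, with a range from 15000 nM to 100000 nM.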

Compound 3, half-maximal inhibitory concentration: 19000 nM
The estimate for compound 3 lay 2.1-fold (0.32 log units) above the measured number, and the stated range covers the measured number.
By their numbers in this assay, from the lowest: compound 3; then compounds 1 and 2 (each within the scatter of the next).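

In this assay this aromatic carbon proves sensitive to what it carries: dimethylamino in place of hydrogen gives a 2.6-fold lower number from compound 2 to compound 3 (0.41 log units; beyond the scatter) and dimethylamino in place of trifluoromethyl gives a 2.2-fold lower number from compound 1 to compound 3 (0.33 log units; beyond the scatter) at the same carbon. Both steps are modest, but both lie beyond the scatter, unlike the earlier exchange of trifluoromethyl for hydrogen, so compound 3 is the strongest inhibitor of the three shown. Nothing available explains why dimethylamino stands apart from the other two groups.

With only hydrogen, trifluoromethyl and dimethylamino shown at this carbon, it remains open whether the lower number is specific to dimethylamino or would also appear with a simple primary amine, a methoxy group or a longer chain ending in an amine. For the compounds shown here, it is also open whether dimethylamino would lower the number in the same way on a different carbon of this ring, or on a core other than the one shared by these compounds.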